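The source may report more compounds than this note shows. Statements on the series, on what has been measured and on what is new or still open speak of the compounds shown alone.

Working notes on the series. Of the compounds shown here, three carry numbers so far. Compound 1 `Nc1ncnc2c1c(-c1ccc3cc[nH]c3c1)cn2-c1ccc(OCCNCCO)cc1` gives 220 nM in an assay on isolated protein for inhibition of Myeloperoxidase (Homo sapiens); on this read-out lower numbers stand for stronger inhibition and higher numbers for weaker inhibition. Compound 2 `FC(F)(F)c1nn(-c2ccc(Cc3nc[nH]n3)cc2)cc1-c1ccc2cc[nH]c2c1` gives 250 nM in this assay. Compound 3 `NC(=O)Cn1cc(-c2ccc3cc[nH]c3c2)c(C(F)(F)F)n1` gives 2000 nM in this assay, the highest of the three numbers; the nearest to it is compound 2, and compound 1 lies a little further off, both gaps beyond the scatter. Compound 4 `N[C@@H]1CC[C@@H](n2cc(-c3ccc4cc[nH]c4c3)c(C(F)(F)F)n2)C1` has not yet been measured. It differs from compound 3 in a single place: a group of 6 heavy atoms (5 carbon, 1 nitrogen; one five-membered non-aromatic ring of carbon only) in place of a group of 4 heavy atoms (2 carbon, 1 nitrogen, 1 oxygen; no ring), on an aromatic nitrogen. For the measured compounds named here, no measured pair changes this position, so the size of the step cannot be read from an earlier example. Going by the values given here, compounds 1 and 2, which carry other substituents on their cores, both give clearly lower numbers than compound 3, and the change in compound 4 replaces the one group that sets compound 3 apart. For compound 4 the expected step from compound 3 is a lower number, a 5.0-fold lower number from compound 3 to compound 4 (0.70 log units; beyond the scatter), beyond the scatter but with wide uncertainty. Compound 4 is therefore estimated at 400 nM in this assay, within a range from 100 nM to 1600 nM.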

Compound 4, half-maximal inhibitory concentration: 70 nM
For compound 4 the middle estimate is 5.7-fold (0.76 log units) above the measured one, and the stated range ends above it.
By their numbers in this assay, from the lowest: compound 4; then compounds 1 and 2 (each within the scatter of the next); then compound 3.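

Putting the group with one five-membered non-aromatic ring of carbon only in place of carbamoylmethyl on the aromatic nitrogen gives a 29-fold lower number from compound 3 to compound 4 (1.46 log units; beyond the scatter) in this assay, so the read-out responds strongly to a change at this position. The two groups carry the same counts of hydrogen-bond donors and acceptors and no net charge, so those counts alone do not separate compound 3 from compound 4. Nothing available bears on why the step is this large.

The compounds shown leave open whether the step goes with the ring, its amine or its 2 defined stereocentres; the bare cyclopentyl ring, an open-chain amine and the other stereoisomers would separate these. From the compounds shown here alone, how a carboxylic acid or a longer chain on the same aromatic nitrogen would read also remains open.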